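The source may report more compounds than this note shows. Statements on the series, on what has been measured and on what is new or still open speak of the compounds shown alone.

Measured in a functional assay on cells for antagonist activity at C-X-C chemokine receptor type 4 (Homo sapiens), read by fluorescence and calcium flux, with stated times of 25 min and 90 s; on this read-out lower numbers stand for stronger inhibition and higher numbers for weaker inhibition:
compound 1, `c1ccc2c(c1)CN[C@@H](CN(CCCCNC1CCOCC1)[C@H]1CCCc3cccnc31)C2`: 29.4 nM
compound 2, `c1ccc2c(c1)CN[C@@H](CN(Cc1ccc(CNC3CCOCC3)cc1)[C@H]1CCCc3cccnc31)C2`: 90.3 nM

Of the two measured compounds, compound 1 gives the lowest number; its nearest neighbour is compound 2, whose number is higher by a margin beyond the usual scatter. The two share a core and differ in the group carried on the amine nitrogen of the chain.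

Compound 3, `C(=C/CN(C[C@H]1Cc2ccccc2CN1)[C@H]1CCCc2cccnc21)\CNCc1ccccn1`, has not yet been measured. It differs from compound 1 in one place: a group of 11 heavy atoms (9 carbon, 2 nitrogen; one six-membered aromatic ring with 1 hetero atom) in place of a group of 10 heavy atoms (8 carbon, 1 nitrogen, 1 oxygen; one six-membered non-aromatic ring with 1 hetero atom), on a saturated chain carbon bound to an amine nitrogen. The 3-((oxan-4-yl)amino)propyl group leaves, and the group that enters brings one six-membered aromatic ring with one hetero atom together with one double bond outside aromatic rings, while the counts of hydrogen-bond donors and acceptors stay the same.

For the measured compounds named here, no measured pair shows this kind of exchange, so the expectation rests on compound 1 alone. Compound 3 is expected to land close to compound 1, with the step of a 1.2-fold lower number from compound 1 to compound 3 (0.07 log units; within the scatter) expected to stay within the scatter, in either direction. The estimate for compound 3 is therefore 25 nM, with a range from 8 nM to 80 nM.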

Compound 3, half-maximal inhibitory concentration: 58.3 nM
For compound 3 the middle estimate is 2.3-fold (0.37 log units) below the measured one, and the stated range covers the measured number.
By their numbers in this assay, from the lowest: compounds 1, 3 and 2 (each within the scatter of the next, the first and the last beyond it).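

In this assay, replacing the 3-((oxan-4-yl)amino)propyl group with a group bearing a six-membered aromatic ring and a double bond outside that ring gives a 2.0-fold higher number from compound 1 to compound 3 (0.30 log units; within the scatter). This position on the saturated chain carbon bound to an amine nitrogen therefore accepts a large change in the group it carries without the read-out moving beyond the usual scatter, and the oxygen-containing non-aromatic ring of compound 1 is not needed for inhibition in this range, as compound 3 lacks it. No measurement shown here offers any explanation for this outcome.

The aromatic ring and the double bond enter together in compound 3, so the compounds shown cannot say what each contributes on its own. Going by these compounds, it also remains open how this position would respond to a group of another kind, such as a primary amine or a carboxylic acid at the end of the chain.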